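The compounds below may be only part of what the source reports. "The series", "measured", "known", "first", "only" and "open" are said of these compounds alone.

Measured compounds:
compound 1 `CCCCCCCCc1ccc(C(=O)C[C@@H]2CCCN2)cc1` — 57%
compound 2 `CCCCCCCCc1ccc(C(C[C@@H]2CCCN2)OC)cc1` — 58%

Both values come from a functional assay on FL5.12 cells (Mus musculus), read by flow cytometry, with a stated time of 3 h, tested at 10 uM; on this read-out lower numbers stand for a weaker effect and higher numbers for a stronger effect at the one concentration tested. In this assay compound 1 gives 57% and compound 2 gives 58%. Compound 1 holds the lower of the two numbers, but the gap to compound 2 lies within the scatter, so the two read as the same on this read-out. Between the two there is a single variation, carbonyl against methoxy-bearing carbon on the chain to the ring, and it leaves the read-out unchanged.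

Compound 3 `CCCCCCCCc1ccc(C(=O)C[C@@H]2C[C@@H](O)CN2)cc1` has not been measured in this assay. Against compound 1 it carries one change: hydroxy in place of hydrogen on a saturated ring carbon. Going by the values given here, nothing measured yet touches this ring carbon, so no step of this kind has a reference. The one variation seen so far, on the chain, left the number unchanged; on that ground the step from compound 1 to compound 3 is expected to be small, perhaps a slight lowering, and not beyond the scatter: a number 5 percentage points lower from compound 1 to compound 3 (within the scatter). For compound 3 the estimated read-out in this assay is 52%, with a range from 30% to 72%.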

Compound 3, a percentage reported as activity, at one concentration (the size of the read-out at that concentration, not a potency): 46%
Compound 3: middle estimate off by 6 percentage points, on the high side, within the range that was stated.
By their numbers in this assay, from the lowest: compound 3; then compounds 1 and 2 (each within the scatter of the next).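

Going by these compounds alone, the ring carbon two ring bonds from the ring nitrogen is the first place where a change moves the number: in this assay, hydroxy in place of hydrogen gives a number 11 percentage points lower from compound 1 to compound 3 (beyond the scatter). The earlier variation, carbonyl against methoxy-bearing carbon on the chain to the ring, left compound 1 and compound 2 within the scatter of each other, so it gave no sign that this ring carbon would respond. The step is modest and compound 3 still gives 46%, so the hydroxy lowers the read-out at the one concentration tested without abolishing it, and no measurement on hand accounts for the step.

On these data alone, whether the lowering is specific to hydroxy or would follow from any group on this ring carbon stays open, and an amine, a fluorine or a carboxylic acid at the same place would help separate the two. Also open, as far as these compounds go, is whether hydroxy gives a step of similar size on the core of compound 2, or alongside a longer chain on the shared core.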